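The source may hold more compounds than are shown below. What is called first, only, known or untested is meant among the compounds shown, and "the series" means these compounds.

Of the compounds shown here, three built on one shared core have been measured in a functional assay on PC-3 cells (Homo sapiens) for inhibition, read by sulforhodamine B assay, with a stated time of 72 h; on this read-out lower numbers stand for stronger inhibition and higher numbers for weaker inhibition. Compound 1 `Nc1sc(-c2ccc(Cl)cc2)c(-c2ccc(Cl)cc2)c1C(=O)N1CCCCC1` gives 14300 nM. Compound 2 `CC1CN(C(=O)c2c(N)sc(-c3ccc(Cl)cc3)c2-c2ccc(Cl)cc2)CCN1` gives 7210 nM, and compound 3 `CC1CCN(C(=O)c2c(N)sc(-c3ccc(Cl)cc3)c2-c2ccc(Cl)cc2)CC1` gives 5750 nM. Among these three numbers compound 2 stands second highest; its nearest neighbour is compound 3, and the step of a 1.3-fold lower number from compound 2 to compound 3 (0.10 log units; within the scatter) lies within the scatter, as does the step of a 2.0-fold lower number from compound 1 to compound 2 (0.30 log units; within the scatter). Going by the values given here, only the step of a 2.5-fold lower number from compound 1 to compound 3 (0.40 log units; beyond the scatter) reaches beyond the scatter, and it is modest.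

Compound 4 `Nc1sc(-c2ccc(Cl)cc2)c(-c2ccc(Cl)cc2)c1C(=O)NC1CCC(O)CC1` has not yet been measured. It differs from compound 2 at the carbonyl carbon: (4-hydroxycyclohexyl)amino in place of 3-methylpiperazin-1-yl on a carbonyl carbon. The two measured steps that also exchange the group on the carbonyl carbon are a 2.0-fold lower number from compound 1 to compound 2 (0.30 log units; within the scatter) and a 1.3-fold lower number from compound 2 to compound 3 (0.10 log units; within the scatter), and both stayed within the scatter. No measured step exchanges 3-methylpiperazin-1-yl for (4-hydroxycyclohexyl)amino, so the incoming group has no direct precedent among these compounds. Because a 2.0-fold lower number from compound 1 to compound 2 (0.30 log units; within the scatter) and a 1.3-fold lower number from compound 2 to compound 3 (0.10 log units; within the scatter) both remained within the scatter, the expected step is a 1.0-fold lower number from compound 2 to compound 4 (0.01 log units; within the scatter), again within the scatter, in no firm direction. For compound 4 in this assay the estimate is 7000 nM, with a range from 2500 nM to 20000 nM.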

Compound 4, half-maximal inhibitory concentration: 5670 nM
For compound 4 the middle estimate is 1.2-fold (0.09 log units) above the measured one; low and high end bracket the measured number.
By their numbers in this assay, from the lowest: compounds 4, 3, 2 and 1 (each within the scatter of the next, the first and the last beyond it).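

In this assay, the carbonyl carbon accepts a group of a new kind: (4-hydroxycyclohexyl)amino has a ring of carbon only and carries an oxygen, yet replacing 3-methylpiperazin-1-yl with it gives a 1.3-fold lower number from compound 2 to compound 4 (0.10 log units; within the scatter), and replacing 4-methylpiperidin-1-yl with it gives a 1.0-fold lower number from compound 3 to compound 4 (0.01 log units; within the scatter). Measured against piperidin-1-yl, the same group gives a 2.5-fold lower number from compound 1 to compound 4 (0.40 log units; beyond the scatter), a modest step beyond the scatter and of the same size as a 2.5-fold lower number from compound 1 to compound 3 (0.40 log units; beyond the scatter), so the change in ring type and attachment at this position leaves the numbers in one narrow band, with only compound 1 set apart from compound 3 and compound 4. Nothing measured alongside these numbers accounts for them.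

Still open, from the compounds shown here alone, is what the hydroxyl itself contributes, which a plain cyclohexylamino group would test, and whether an amine or a carboxylic acid at the same ring carbon would move the number beyond the scatter. Going by these compounds, it is equally open whether a longer chain, such as (4-hydroxybutyl)amino, would hold the number in this band without any ring on the carbonyl carbon.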